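A few compounds are considered here, and "the series" means these few. Any claim that something is new, unique, unknown or untested is made for them only; others in the source may bear on it.

Measured compounds:
Compound 1, `COc1ccc(C(=O)NCCNc2nc3cc(C)cc(C)c3cc2C#N)cc1`: 3000 nM
Compound 2, `Cc1cc(C)c2cc(C#N)c(NCCNC(=O)c3cccnc3)nc2c1`: 2700 nM
Compound 3, `Cc1cc(C)c2cc(C#N)c(NCCNC(=O)c3ccncc3)nc2c1`: 7300 nM

These three compounds share a core and differ only in the aryl group on the carbonyl carbon of the amide. In an in vitro assay on FRT cells with Cystic fibrosis transmembrane conductance regulator variant F508del (Homo sapiens) as the target, read by fluorescence, with a stated time of 24 h, at 37 degrees C, in the presence of a further agent that is not named here (a higher number here means that more compound is needed for the effect, a lower number that less compound is needed), compound 3 stands at the highest of the three numbers; compound 1 is the nearest to it and compound 2 the furthest, and both steps to compound 3 lie beyond the scatter: a 2.4-fold higher number from compound 1 to compound 3 (0.39 log units; beyond the scatter) and a 2.7-fold higher number from compound 2 to compound 3 (0.43 log units; beyond the scatter). Between compound 1 and compound 2 the step is small, a 1.1-fold lower number from compound 1 to compound 2 (0.05 log units; within the scatter).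

Compound 4, `Cc1cc(C)c2cc(C#N)c(NCCNC(=O)c3ccccc3)nc2c1`, is not yet measured. It differs from compound 3 in one place: phenyl in place of pyridin-4-yl on a carbonyl carbon.

Going by the values given here, two measured steps bear on this change. Both show that the pyridin-4-yl group on the carbonyl carbon gives a higher number than either of the other aryl groups tested there, by modest amounts in this assay. Replacing it with phenyl is therefore expected to move the number down by a similar, modest size, the estimated step being a 2.1-fold lower number from compound 3 to compound 4 (0.32 log units; beyond the scatter). Compound 4 is accordingly expected to give about 3500 nM in this assay, with a likely range from 1500 nM to 8000 nM.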

Compound 4, half-maximal effective concentration: "not active" (no number reported)
Nothing numeric was reported for compound 4; no gap can be computed for the estimate.
By their numbers in this assay, from the lowest: compounds 2 and 1 (each within the scatter of the next); then compound 3.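

In this assay, going by these compounds alone, compound 4 was reported as "not active" with no number, so no step to it from compound 3 or any other compound can be read. The compounds shown leave open where compound 4 would fall numerically relative to compound 3. Nothing given here bears on this result.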